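Amino Group Enters the Core of Compound 2

The compounds below may be only part of what the source reports. "The series", "measured", "known", "first", "only" and "open" are said of these compounds alone.

Of the compounds shown here, three have been measured in a functional assay on EKVX cells (Homo sapiens) for cytotoxicity, read by sulforhodamine B assay, with a stated time of 48 h; a higher number here means a weaker inhibitor of growth, a lower number a stronger inhibitor of growth. Compound 1 `ClCc1ccccc1Cn1cnc2c(Cl)nc(Cl)nc21` gives 1770 nM, and compound 3 `ClCc1ccc(Cn2cnc3nc(Cl)nc(Cl)c32)cc1` gives 1900 nM. Compound 2 `ClCc1ccccc1Cn1cnc2c(Cl)ncnc21` gives 3090 nM, a number that lies within the scatter of both companions, so no order among the three can be read. For the measured compounds named here, the only step joining two measured compounds, a 1.7-fold higher number from compound 1 to compound 2 (0.24 log units; within the scatter), also stays within the scatter. Compound 4 `Nc1nc(Cl)c2ncn(Cc3ccccc3CCl)c2n1` has not been measured; it differs from compound 2 by amino in place of hydrogen on an aromatic carbon. Going by the values given here, no measured step shows what an entering amino group does in this assay, so the expected step, a 1.0-fold lower number from compound 2 to compound 4 (0.01 log units; within the scatter), is none beyond the scatter. Compound 4 is therefore estimated at 3000 nM, with a range from 1200 nM to 8000 nM.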

Compound 4, concentration for 50% growth inhibition: 15900 nM
Compound 4: the middle estimate sits 5.3-fold (0.72 log units) below what was measured, outside the stated range (above it).
By their numbers in this assay, from the lowest: compounds 1, 3 and 2 (each within the scatter of the next); then compound 4.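

In this assay amino in place of hydrogen brought a 5.1-fold higher number from compound 2 to compound 4 (0.71 log units; beyond the scatter) and amino in place of chloro brought a 9.0-fold higher number from compound 1 to compound 4 (0.95 log units; beyond the scatter) at this position between two ring nitrogen atoms, whereas hydrogen in place of chloro there had stayed within the scatter. This position therefore does respond to change, and the response comes with the entering amino group rather than with the loss of chloro. Nothing measured here accounts for the shift.

As far as these compounds go, whether a methylamino or a hydroxyl group at this position would behave as amino does remains open. So does whether amino brings the same step on the benzyl arrangement of compound 3.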